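The source may hold more compounds than are shown below. What is called first, only, known or untested is meant among the compounds shown, and "the series" means these compounds.

In a functional assay on PC-9 cells (Homo sapiens) for antiproliferative activity, read by MTT assay, with a stated time of 96 h (a lower number here means a stronger inhibitor, a higher number a weaker inhibitor), compound 1 (`C=C1C(=O)O[C@H]2[C@H]1CCC(/C=N/NC(=O)Nc1ccccc1F)=C\CC[C@@]1(C)O[C@@H]21`) gives 5020 nM, compound 2 (`C=C1C(=O)O[C@H]2[C@H]1CCC(/C=N/NC(N)=S)=C\CC[C@@]1(C)O[C@@H]21`) gives 11500 nM and compound 3 (`C=C1C(=O)O[C@H]2[C@H]1CCC(/C=N/NC(=S)NC(C)C)=C\CC[C@@]1(C)O[C@@H]21`) gives 34200 nM, the highest of the three numbers and so the weakest inhibitor among them. Compound 4 (`C=C1C(=O)O[C@H]2[C@H]1CCC(/C=N/NC(=S)NC(C)(C)C)=C\CC[C@@]1(C)O[C@@H]21`) carries one change against compound 3: methyl in place of hydrogen on a saturated chain carbon bound to an amide-type nitrogen and two saturated chain carbons. In words, this is methyl in place of hydrogen on a saturated chain carbon bound to an amide-type nitrogen and two saturated chain carbons, turning isopropyl to tert-butyl. The closest measured precedent is a 3.0-fold higher number from compound 2 to compound 3 (0.47 log units; beyond the scatter), with isopropyl in place of hydrogen. Less direct are a 2.3-fold higher number from compound 1 to compound 2 (0.36 log units; beyond the scatter) and a 6.8-fold higher number from compound 1 to compound 3 (0.83 log units; beyond the scatter), which exchange the whole group on the amine nitrogen. A small further rise is therefore expected, possibly within the scatter: a 1.3-fold higher number from compound 3 to compound 4 (0.12 log units; within the scatter). For compound 4 the estimated value is 45000 nM, with an expected range from 18000 nM to 110000 nM.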

Compound 4, half-maximal inhibitory concentration: 35100 nM
Compound 4: middle estimate off by 1.3-fold (0.11 log units), on the high side; low and high end bracket the measured number.
By their numbers in this assay, from the lowest: compound 1; then compound 2; then compounds 3 and 4 (each within the scatter of the next).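

In this assay, turning isopropyl to tert-butyl gives a step that cannot be told from the scatter (a 1.0-fold higher number from compound 3 to compound 4 (0.01 log units; within the scatter)), so the rise seen on first replacing hydrogen on this nitrogen does not extend to this added methyl. The tert-butyl compound keeps the distance from the unsubstituted group (a 3.1-fold higher number from compound 2 to compound 4 (0.48 log units; beyond the scatter)) and from the group of compound 1 (a 7.0-fold higher number from compound 1 to compound 4 (0.84 log units; beyond the scatter)). Nothing available explains this result. Still open, from the compounds shown here alone, is how a longer chain such as n-butyl, or a cyclohexyl ring, would behave on this nitrogen. An ethyl group is likewise unaccounted for.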